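The compounds below may be only part of what the source reports. "The series", "measured", "known", "first", "only" and "open" are said of these compounds alone.

Measured so far in a functional assay on the whole organism (strain Albino) for inhibition, with Rattus norvegicus as the target, with stated times of 1 h and 2 h, at a dose of 20 mg/kg by the oral route; a higher number here means more inhibition at the dose given (going by the name of the read-out), a lower number less inhibition:
compound 1 `O=C(O)CCC1=C(c2ccc(Cl)cc2)NC(=S)NC1c1ccccc1O` gives 14.7%
compound 2 `O=C(O)CCC1=C(c2ccc(Cl)cc2)NC(=S)NC1c1ccco1` gives 17.9%

Compound 2 stands at the upper end of the two numbers shown, yet the step of a number 3.2 percentage points higher from compound 1 to compound 2 (within the scatter) lies within the scatter, so compound 1 and compound 2 are not distinguished by this assay. Compound 3 `Cc1ccc(C2=C(CCC(=O)O)C(c3ccco3)NC(=S)N2)cc1` differs from compound 2 by methyl in place of chloro on an aromatic carbon. Among the measured compounds shown here, the one measured step, a number 3.2 percentage points higher from compound 1 to compound 2 (within the scatter), concerns the group on the saturated ring carbon, not the aromatic carbon changed here; no measured step therefore bears on the chloro-to-methyl exchange, and nothing speaks for a shift beyond the scatter in this assay in either direction. Compound 3 is accordingly expected to come out close to compound 2, estimated at 17% with a range of 6% to 29%. The expected step is a number 0.9 percentage points lower from compound 2 to compound 3 (within the scatter), within the scatter.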

Compound 3, a percentage reported as inhibition, in the whole organism at one dose (the size of the read-out at that dose, not a potency): 28.1%
Estimate against measurement, compound 3: 11.1 percentage points below, within the range that was stated.
By their numbers in this assay, from the lowest: compounds 1 and 2 (each within the scatter of the next); then compound 3.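

In this assay, among the compounds shown here, 4-methylphenyl in place of 4-chlorophenyl gives a number 10.2 percentage points higher from compound 2 to compound 3 (beyond the scatter), the only step so far that lies beyond the scatter, though it is modest. The aromatic carbon para to a large group is therefore a place where this read-out can move, whereas the exchange on the saturated ring carbon, a number 3.2 percentage points higher from compound 1 to compound 2 (within the scatter), does not separate its two compounds. No available evidence bears on this step.

Going by these compounds, whether methyl in place of chloro gives a similar step with 2-hydroxyphenyl on the saturated ring carbon remains open. Also open, on these data alone, is how this assay responds to a methoxy group, a fluorine atom or a trifluoromethyl group on the same aromatic carbon, or to a methyl ester in place of the carboxylic acid.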